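The compounds below may be only part of what the source reports. "The series", "measured", "known", "first", "only" and "open" are said of these compounds alone.

Compound 1 `Cc1cc(-c2c(C)nn(C)c2C)ccc1-c1nnc(N(C)Cc2ccc3nccn3c2)o1` gives 79.4 nM in an assay on isolated protein for inhibition of tyrosine-protein kinase receptor UFO (Homo sapiens), read by LC-MS; on this read-out lower numbers stand for stronger inhibition and higher numbers for weaker inhibition.
Compound 2 `Cc1cc(-c2c(C#N)nn(C)c2C)ccc1-c1nnc(N(C)Cc2ccc3nccn3c2)o1` gives 6310 nM in this assay.

Of these two numbers, compound 2 stands highest, which means it is the weaker inhibitor of the pair. Among the compounds with values here, the only measured step, a 79-fold higher number from compound 1 to compound 2 (1.90 log units; beyond the scatter), is large and bears directly on the change to compound 3 `Cc1cc(-c2c(C)nn(C(F)F)c2C)ccc1-c1nnc(N(C)Cc2ccc3nccn3c2)o1`, which carries 1-(difluoromethyl)-3,5-dimethyl-1H-pyrazol-4-yl in place of 3-cyano-1,5-dimethyl-1H-pyrazol-4-yl on an aromatic carbon. In that change the cyano of compound 2 disappears and a methyl stands in its place, as in compound 1, while a difluoromethyl enters where one methyl stood. The return to methyl is expected to lower the number by roughly the amount it rose because a 79-fold higher number from compound 1 to compound 2 (1.90 log units; beyond the scatter) covers exactly that swap. The difluoromethyl has no measured counterpart among these compounds, so its contribution is unknown. Compound 3 is therefore expected to give about 100 nM in this assay, within 30 nM to 400 nM. This amounts to an expected step of a 63-fold lower number from compound 2 to compound 3 (1.80 log units; beyond the scatter).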

Compound 3, half-maximal inhibitory concentration: 63100 nM
Estimate against measurement, compound 3: 630-fold (2.80 log units) below; the whole stated range lies below it.
By their numbers in this assay, from the lowest: compound 1; then compound 2; then compound 3.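

On the aromatic nitrogen, difluoromethyl in place of methyl gives a 790-fold higher number from compound 1 to compound 3 (2.90 log units; beyond the scatter) in this assay, so this position, which had not been varied before, is at least as sensitive as the cyano-bearing carbon, where the earlier change gave a 79-fold higher number from compound 1 to compound 2 (1.90 log units; beyond the scatter). Putting 1-(difluoromethyl)-3,5-dimethyl-1H-pyrazol-4-yl in place of 3-cyano-1,5-dimethyl-1H-pyrazol-4-yl gives a 10-fold higher number from compound 2 to compound 3 (1.00 log units; beyond the scatter), which shows that removing the cyano does not bring the number back down when the nitrogen carries difluoromethyl. Nothing available explains why this nitrogen change weakens inhibition so strongly.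

The compounds shown leave open whether the fluorine atoms themselves matter or whether any group other than methyl on that nitrogen has a similar result. Ethyl, monofluoromethyl or a plain hydrogen at the same nitrogen would help separate these possibilities.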